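Swapping Trifluoromethyl for an Ester: An Expected Read-out

This account rests on a few compounds, and the source may have more. Where it says the series, first, only, none or still open, it means among the compounds named here.

Three compounds have been measured so far:

Compound 1, `C[C@H](NC(=O)Nc1cccc(C(F)(F)F)c1)c1ccccc1`, in an ADME assay on the whole organism with Oryza sativa as the target, tested at 1 uM (on this read-out higher numbers stand for a weaker effect at the one concentration tested and lower numbers for a stronger effect), gives 93%.
Compound 2, `C[C@@H](NC(=O)Nc1ccc(C(F)(F)F)cc1)c1ccccc1`, in this assay gives 89%.
Compound 3, `CCOC(=O)c1cccc(NC(=O)N[C@@H](C)c2ccccc2)c1`, in this assay gives 99%.

For the measured compounds named here, all three numbers lie close together, and none of the gaps between them is beyond the usual scatter of this kind of measurement, so no compound can be singled out as stronger or weaker than another.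

One structural change appears in measured form. Compound 3 differs from compound 1 by ethoxycarbonyl in place of trifluoromethyl on an aromatic carbon. That change made a number 6 percentage points higher from compound 1 to compound 3 (within the scatter).

Compound 4, `CCOC(=O)c1ccc(NC(=O)N[C@H](C)c2ccccc2)cc1`, has not yet been measured. It differs from compound 2 by ethoxycarbonyl in place of trifluoromethyl on an aromatic carbon. Compound 1 and compound 2 share the same atoms joined differently; the difference between the two cores is not broken down here. The change from compound 2 to compound 4 is the same kind of change as from compound 1 to compound 3, but not the same: in one case the place is meta to a large group, in the other it is para to a large group.

Because the earlier change gave a number 6 percentage points higher from compound 1 to compound 3 (within the scatter), a step of similar small size is expected here, a number 6 percentage points higher from compound 2 to compound 4 (within the scatter). Compound 4 is therefore estimated to give 95%, with a likely range from 86% to 100%.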

Compound 4, a percentage reported as activity, at one concentration (the size of the read-out at that concentration, not a potency): 100%
For compound 4 the middle estimate is 5 percentage points below the measured one; measured number inside the range.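

On the second core, ethoxycarbonyl in place of trifluoromethyl gave a number 11 percentage points higher from compound 2 to compound 4 (beyond the scatter), and the two steps for this change do not differ by more than repeated measurements of this kind would allow: the same change on two cores in this assay, a number 6 percentage points higher (within the scatter) from compound 1 to compound 3 and a number 11 percentage points higher (beyond the scatter) from compound 2 to compound 4, 5 percentage points apart, within the scatter of two such steps

Taken together, the two pairs give no sign that the choice of core alters what this swap does in this assay. For the compounds shown here, that is not proof that the step has the same size on both cores or that it would hold on a third one: only one of the two steps lies beyond the scatter, there are only two pairs, and the group sits in a different place on the ring in each pair, so any effect of the core cannot be separated from any effect of that place.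

The compounds shown leave open how other groups in the same place would read in this assay, for example a carboxylic acid, an amine or a nitrile. They also leave open whether a longer chain in place of the ethyl part of the ester would give a number clearly different from that of compound 4, which gives 100%.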